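Swapping a branched ether for an ester on the core

The source may report more compounds than this note shows. Statements on the series, on what has been measured and on what is new or still open speak of the compounds shown alone.

Among the compounds with values here, compound 2 `COC(C)c1cc(-c2ccccc2)c2ccc(OCc3cccc(C4(O)CCOCC4)c3)cc2c1` gives 1200 nM in an assay on isolated protein with Polyunsaturated fatty acid 5-lipoxygenase (Homo sapiens) as the target (a lower number here means a stronger inhibitor, a higher number a weaker inhibitor), the highest of the two numbers measured so far. Within the data shown here, its nearest neighbour, compound 1 `COCc1cc(-c2ccccc2)c2ccc(OCc3cccc(C4(O)CCOCC4)c3)cc2c1`, gives 160 nM in this assay, and the only measured step, a 7.5-fold higher number from compound 1 to compound 2 (0.88 log units; beyond the scatter), shows that methyl in place of hydrogen went with weaker inhibition. Compound 3 `COC(=O)c1cc(-c2ccccc2)c2ccc(OCc3cccc(C4(O)CCOCC4)c3)cc2c1` differs from compound 2 by methoxycarbonyl in place of 1-methoxyethyl on an aromatic carbon. Among the measured compounds shown here, this change removes the methyl that set compound 2 apart from compound 1, but it also turns a saturated carbon into a carbonyl, a change no measured pair covers, so the step from compound 1 to compound 2 bears on it only in part. Because a 7.5-fold higher number from compound 1 to compound 2 (0.88 log units; beyond the scatter) was modest, compound 3 is expected to recover part of that loss, an estimated step of a 3.4-fold lower number from compound 2 to compound 3 (0.54 log units; beyond the scatter). Compound 3 is therefore estimated at 350 nM, within a range of 90 nM to 1400 nM.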

Compound 3, half-maximal inhibitory concentration: 70 nM
The estimate for compound 3 lay 5.0-fold (0.70 log units) above the measured number; the whole stated range lies above it.
By their numbers in this assay, from the lowest: compound 3; then compound 1; then compound 2.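

In this assay, methoxycarbonyl in place of 1-methoxyethyl on this aromatic carbon gives a 17-fold lower number from compound 2 to compound 3 (1.23 log units; beyond the scatter), which is labelled a large step. Methoxycarbonyl in place of methoxymethyl gives a 2.3-fold lower number from compound 1 to compound 3 (0.36 log units; beyond the scatter), so the ester does more than win back what the extra methyl lost: it also moves past the unbranched ether, and this position accepts a carbonyl carbon in place of a saturated one. Nothing available here explains why the ester gives the lowest number of the three.

From the compounds shown here alone, whether this trend extends to a carboxylic acid or an amide on the same aromatic carbon remains open. So does the effect of a longer chain in place of the ester's methyl group.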